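The compounds below may be only part of what the source reports. "The series", "measured", "known", "first", "only" and "open" are said of these compounds alone.

Compound 1 `COc1cc2c(Oc3ccc(NC(=O)c4cc(-c5ccccc5)nc5ccc(F)cc45)cc3F)ccnc2cc1OCCCN1CCCC1` gives 110 nM in a functional assay on MKN-45 cells (Homo sapiens) for cytotoxicity, read by MTT assay, with a stated time of 72 h; a higher number here means a weaker inhibitor, a lower number a stronger inhibitor.
Compound 2 `COc1cc2c(Oc3ccc(NC(=O)c4cc(-c5cccc(Cl)c5)nc5ccc(F)cc45)cc3F)ccnc2cc1OCCCN1CCCC1` gives 67 nM in this assay.

Compound 2 has the lower of the two numbers, with compound 1 the nearest by a 1.6-fold lower number from compound 1 to compound 2 (0.22 log units; within the scatter), a gap that does not rise above the scatter of this kind of measurement. Compound 3 `COc1ccc(-c2cc(C(=O)Nc3ccc(Oc4ccnc5cc(OCCCN6CCCC6)c(OC)cc45)c(F)c3)c3cc(F)ccc3n2)cc1` differs from compound 2 in one place: 4-methoxyphenyl in place of 3-chlorophenyl on an aromatic carbon. Among the measured compounds shown here, the only measured step bears on the same ring, where chlorine replaced hydrogen, and it was a 1.6-fold lower number from compound 1 to compound 2 (0.22 log units; within the scatter), within the scatter. Changing one group on this ring has so far moved the number little, so for compound 3 the expected step is a 1.5-fold higher number from compound 2 to compound 3 (0.17 log units; within the scatter), no larger than the scatter and in no sure direction. The estimate for compound 3 in this assay is 100 nM, with a range from 40 nM to 300 nM.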

Compound 3, half-maximal inhibitory concentration: 170 nM
Beside the measured number, compound 3's estimate is 1.7-fold (0.23 log units) below it, within the range that was stated.
By their numbers in this assay, from the lowest: compounds 2, 1 and 3 (each within the scatter of the next, the first and the last beyond it).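

In this assay this position shows its first step beyond the scatter, with a 2.5-fold higher number from compound 2 to compound 3 (0.40 log units; beyond the scatter) when 4-methoxyphenyl replaces 3-chlorophenyl, so the group on this ring can move the number modestly. Against the plain phenyl ring, adding methoxy gives only a 1.5-fold higher number from compound 1 to compound 3 (0.19 log units; within the scatter) and stays within the scatter, as the chloro step did, so compound 1 stands clearly apart from neither; only the two substituted rings separate. This swap changes both the group and where it sits on the ring, and no measurement at hand explains the gap.

Results for 3-methoxyphenyl and 4-chlorophenyl would show whether the gap follows the group or its place on the ring. Also open, on these data alone, is how this position would respond to a ring carrying an amine or a carboxylic acid.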